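The compounds below may be only part of what the source reports. "The series", "measured", "known", "first", "only" and "open" are said of these compounds alone.

Measured in a toxicity assay on HeLa cells (Homo sapiens) for cytotoxicity, read by colorimetric assay, with a stated time of 72 h; a higher number here means that more compound is tolerated, a lower number that less compound is tolerated:

- Compound 1 `O=c1nc(N2CC[C@@H](c3ccc(F)cc3)[C@H](O)C2)sc2c([N+](=O)[O-])cc(C(F)(F)F)cc12`: 68400 nM
- Compound 2 `O=c1nc(N2CC[C@@H](c3ccc(F)cc3)[C@H](CO)C2)sc2c([N+](=O)[O-])cc(C(F)(F)F)cc12`: 35800 nM
- Compound 3 `N#Cc1cccc(N2CCN(c3nc(=O)c4cc(C(F)(F)F)cc([N+](=O)[O-])c4s3)CC2)c1`: > 108000 nM, a limit and not a number

Compound 3 gives no exact value, only (the limit of > 108000 nM in this assay, at which 1 of the 3 values shown sits). Compound 4 `O=C(CN1CCN(c2nc(=O)c3cc(C(F)(F)F)cc([N+](=O)[O-])c3s2)CC1)NCc1ccccc1` is compound 3 with (benzylcarbamoyl)methyl in place of 3-cyanophenyl on an amine nitrogen in a ring.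

Among the compounds with values here, no measured step covers this swap. Within the data shown here, the only measured step is a 1.9-fold lower number from compound 1 to compound 2 (0.28 log units; within the scatter). It replaces hydroxy with hydroxymethyl on a saturated ring carbon, a different change at a different place, so it bears only loosely on this one. Still, it gives no sign that a change around the shared core moves the number far.

Compound 4 keeps that core, so it is expected to land in the same region as compound 1 at 68400 nM. It could also give only a limit again. The expected step is an at least 1.6-fold lower number from compound 3 to compound 4 (0.22 log units; that floor lies within the scatter), a rough figure towards a lower number that starts from a limit. For compound 4 the estimate is 65000 nM, with an expected range from 25000 nM to 110000 nM.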

Compound 4, half-maximal cytotoxic concentration: 57100 nM
Compound 4: the middle estimate sits 1.1-fold (0.06 log units) above what was measured; low and high end bracket the measured number.
By their numbers in this assay, from the lowest: compounds 2, 4 and 1 (each within the scatter of the next). At a limit, above all of these: compound 3.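

On the amine nitrogen in the ring, (benzylcarbamoyl)methyl in place of 3-cyanophenyl gives an at least 1.8-fold lower number from compound 3 to compound 4 (0.27 log units; that floor lies within the scatter) in this assay. Compound 3 has only a limit and not a number: the limit of > 108000 nM in this assay, at which 1 of the 4 values shown sits. On these data alone, compound 4 shows that this ring nitrogen can carry a group with a carbonyl and an amide hydrogen and still return an exact number, but the true size of the step remains unknown, and its floor alone does not establish a real shift.

The compounds shown do not separate the part played by the benzyl end from that of the amide within the new group. Also open, as far as these compounds go, is how a carboxylic acid, a primary amine or a longer chain at this ring nitrogen would read in this assay.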